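The source may report more compounds than this note shows. Statements on the series, on what has been measured and on what is new or still open speak of the compounds shown alone.

Measured so far in a functional assay on NCI-H460 cells (Homo sapiens) for antiproliferative activity, read by MTT assay, with a stated time of 72 h; on this read-out higher numbers stand for weaker inhibition and lower numbers for stronger inhibition:
- compound 1 `CN(C)CCCn1cnnc1-c1cc(Oc2ccc(NC(=O)Nc3ccc(Cl)c(C(F)(F)F)c3)cc2F)ccn1`: 1680 nM
- compound 2 `CN(C)CCCn1cnnc1-c1cc(Oc2ccc(NC(=O)Nc3ccc(F)c(F)c3)cc2F)ccn1`: 1080 nM

Going by the values given here, compound 2 holds the lowest of the two numbers, and its nearest neighbour is compound 1; the one step that joins them, a 1.6-fold lower number from compound 1 to compound 2 (0.19 log units; within the scatter), is within the scatter, so the two compounds cannot be ordered on this assay.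

Compound 3 `CN(C)CCCn1cnnc1-c1cc(Oc2ccc(NC(=O)Nc3ccc(Cl)cc3Cl)cc2F)ccn1` has not yet been measured. It differs from compound 2 in one place: 2,4-dichlorophenyl in place of 3,4-difluorophenyl on an amide-type nitrogen. Among the compounds with values here, the only measured step that bears on this change is the same kind of exchange at the same position, the aryl swap on the amide-type nitrogen read as a 1.6-fold lower number from compound 1 to compound 2 (0.19 log units; within the scatter), and that step stayed within the scatter. With one such step on record, and it flat, the expectation for the move to a third aryl group at that nitrogen is a step of no more than scatter size, estimated as a 1.2-fold higher number from compound 2 to compound 3 (0.08 log units; within the scatter).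

On that basis compound 3 is expected to give about 1300 nM in this assay, with a range from 500 nM to 3500 nM.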

Compound 3, half-maximal inhibitory concentration: 3680 nM
Compound 3: the middle estimate sits 2.8-fold (0.45 log units) below what was measured; measured number outside the range, above it.
By their numbers in this assay, from the lowest: compounds 2 and 1 (each within the scatter of the next); then compound 3.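

The aryl group on the amide-type nitrogen is not a silent position in this assay: with 2,4-dichlorophenyl in that place, a 3.4-fold higher number from compound 2 to compound 3 (0.53 log units; beyond the scatter) and a 2.2-fold higher number from compound 1 to compound 3 (0.34 log units; beyond the scatter) are both beyond the scatter, though modest in size. The earlier pair, with 3,4-difluorophenyl and 4-chloro-3-(trifluoromethyl)phenyl, could not be ordered, so this position looked flat; compound 3 shows that not every aryl exchange here is neutral, and that this one goes towards weaker inhibition. The data on hand offer no measurement that accounts for this shift.

With three aryl groups on record, the step cannot be assigned to the chlorine atoms themselves or to the arrangement printed in the name 2,4-dichlorophenyl, since compound 1 also carries chlorine and stays within the scatter of compound 2; 3,4-dichlorophenyl and 2,4-difluorophenyl on the same nitrogen would separate the two readings. Also open, from the compounds shown here alone, is how an unsubstituted phenyl ring would read at this nitrogen, and whether the step holds in any test other than this single cell line.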